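Permeability notes: from compound 2 to compound 3

This account rests on a few compounds, and the source may have more. Where it says the series, first, only, none or still open, it means among the compounds named here.

In an ADME assay on MDCKII-LE cells (Canis lupus familiaris) for permeability (on this read-out lower numbers stand for lower permeability and higher numbers for higher permeability), compound 1 `N#C[C@H]1C[C@@H](CN([C@H](CCC(F)(F)F)C(N)=O)S(=O)(=O)c2ccc(Cl)cc2)C1` gives 24.1 10^-6 cm/s and compound 2 `C[C@]1(C#N)C[C@@H](CN([C@H](CCC(F)(F)F)C(N)=O)S(=O)(=O)c2ccc(Cl)cc2)C1` gives 25.7 10^-6 cm/s, so compound 2 stands level with compound 1 within the scatter. Compound 3 `NC(=O)[C@@H](CCC(F)(F)F)N(C[C@H]1C[C@@H](c2ncon2)C1)S(=O)(=O)c1ccc(Cl)cc1` is still unmeasured and carries 3-(1,2,4-oxadiazol-3-yl)cyclobutyl in place of 3-cyano-3-methylcyclobutyl on a saturated chain carbon bound to a sulfonamide nitrogen: 3-(1,2,4-oxadiazol-3-yl)cyclobutyl in place of 3-cyano-3-methylcyclobutyl. Among the measured compounds shown here, the only measured step at this place is a 1.1-fold higher number from compound 1 to compound 2 (0.03 log units; within the scatter). It is a different change, so it guides this one only loosely. An estimated step of a 1.4-fold lower number from compound 2 to compound 3 (0.13 log units; within the scatter) is expected, not beyond the scatter. For compound 3 the estimated value is 19 10^-6 cm/s, with an expected range of 9 10^-6 cm/s to 33 10^-6 cm/s.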

Compound 3, apparent permeability: 14.1 10^-6 cm/s
Compound 3: the middle estimate sits 1.3-fold (0.13 log units) above what was measured; measured number inside the range.
By their numbers in this assay, from the lowest: compounds 3, 1 and 2 (each within the scatter of the next).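

In this assay, among the compounds shown here, the first heteroaromatic group at this position leaves the read-out within the scatter: a 1.8-fold lower number from compound 2 to compound 3 (0.26 log units; within the scatter), and a 1.7-fold lower number from compound 1 to compound 3 (0.23 log units; within the scatter). The 1,2,4-oxadiazol-3-yl ring thus takes the place of cyano on a saturated ring carbon without a step beyond the scatter, so this position accepts more than the two nitrile-bearing cyclobutyl groups. No measurement shown accounts for these steps. Still open, going by these compounds, is whether a carboxylic acid or an amine on the cyclobutyl ring would also stay within the scatter of these three compounds.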